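Purine series: chloro removal on the six-membered ring

The source may report more compounds than this note shows. Statements on the series, on what has been measured and on what is new or still open speak of the compounds shown alone.

Two compounds of the shared core carry the measured values. Compound 1 `ClCc1ccc(Cn2cnc3c(Cl)ncnc32)cc1` is read only as a limit of the assay: in a functional assay on PC-3 cells (Homo sapiens) for cytotoxicity, read by sulforhodamine B assay, with a stated time of 48 h (a lower number here means that less compound is tolerated, a higher number that more compound is tolerated), compound 1 gives > 100000 nM. Among the measured compounds shown here, compound 2 `ClCc1ccc(Cn2cnc3nc(Cl)nc(Cl)c32)cc1` is the only member with a number: in this assay compound 2 gives 75900 nM. For the measured compounds named here, compound 2 therefore stands as the sole quantified point, the other value being a limit (the limit of > 100000 nM in this assay, at which 1 of the 2 values shown sits), so no measured step can be drawn.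

Compound 3 `ClCc1ccc(Cn2cnc3ncnc(Cl)c32)cc1` differs from compound 2 by hydrogen in place of chloro on an aromatic carbon, a hydrogen in place of chloro on an aromatic carbon, the position lying between two ring nitrogen atoms of the six-membered aromatic ring that is part of the fused system. The remaining chloro on that ring is kept. With compound 1, which lacks a second chloro, sitting at its limit of > 100000 nM, the expectation for compound 3 is a step toward weaker cytotoxicity, a 2.0-fold higher number from compound 2 to compound 3 (0.30 log units; within the scatter), beyond the usual scatter and with a real chance that only a limit is returned. The estimate for compound 3 in this assay is 150000 nM, expected to fall between 50000 nM and 500000 nM.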

Compound 3, concentration lethal to 50% of the cells: 5370 nM
Compound 3: the middle estimate sits 28-fold (1.45 log units) above what was measured, and the stated range ends above it.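

In this assay, among the compounds shown here, hydrogen in place of chloro on the aromatic carbon between two ring nitrogen atoms gives a 14-fold lower number from compound 2 to compound 3 (1.15 log units; beyond the scatter), which is the only measured step so far and a large one. A chloro at this position is therefore not required for cytotoxicity on these cells in this series, and its replacement by hydrogen, with the other chloro kept, moves the number down well beyond the scatter, with compound 3 at 5370 nM. Steps involving compound 1 cannot be read, as its entry is a limit and not a number: the limit of > 100000 nM in this assay, at which 1 of the 3 values shown sits.

What the remaining chloro, which is meta to the changed position, contributes in this assay stays open, since no listed step replaces it on its own. As far as these compounds go, it is also open whether the drop in the number is specific to hydrogen at this position or would hold for an amine or a methoxy group there, and whether it carries over when the chloromethyl group on the benzene ring is replaced.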